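A trifluoromethyl swap on compound 3

A few compounds are considered here, and "the series" means these few. Any claim that something is new, unique, unknown or untested is made for them only; others in the source may bear on it.

In a functional assay on MCF7 cells (Homo sapiens) for antiproliferative activity, read by MTT assay, with a stated time of 48 h (a higher number here means a weaker inhibitor, a lower number a stronger inhibitor), compound 3 (`COc1ccc(-c2c(Nc3ccc(C)c(O)c3)c3ccc(O)cc3oc2=O)cc1`) gives > 100000 nM, which is a limit of the assay and not a number.

Compound 4 (`COc1ccc(-c2c(Nc3cccc(C(F)(F)F)c3)c3ccc(O)cc3oc2=O)cc1`) has 3-(trifluoromethyl)phenyl in place of 3-hydroxy-4-methylphenyl on the nitrogen: 3-(trifluoromethyl)phenyl in place of 3-hydroxy-4-methylphenyl on a nitrogen on an aromatic ring.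

The nearest guide is compound 2 (`COc1ccc(-c2c(Nc3ccc(F)cc3)c3ccc(O)cc3oc2=O)cc1`), which has the same core with 4-fluorophenyl on that nitrogen and gives 71500 nM. Changing that group has so far given an at least 1.3-fold higher number from compound 2 to compound 3 (0.14 log units; that floor lies within the scatter).

Compound 1 (`COc1ccc(-c2c(Nc3ccc(C)c(O)c3)c3ccccc3oc2=O)cc1`) lacks one core hydroxy and gives 12100 nM. Adding that hydroxy gave an at least 8.2-fold higher number from compound 1 to compound 3 (0.91 log units; beyond the scatter).

Compound 4 keeps the hydroxy, so like compound 2 at 71500 nM it is expected to stay weak.

Only a small step towards a lower number is expected, estimated as an at least 1.4-fold lower number from compound 3 to compound 4 (0.15 log units; that floor lies within the scatter).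

For compound 4, the estimate is 70000 nM, with an expected range of 30000 nM to 100000 nM.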

Compound 4, half-maximal inhibitory concentration: 49100 nM
Beside the measured number, compound 4's estimate is 1.4-fold (0.15 log units) above it, and the stated range covers the measured number.
By their numbers in this assay, from the lowest: compound 1; then compounds 4 and 2 (each within the scatter of the next). At a limit, above all of these: compound 3.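

Compound 3 stands at a limit of the assay, not at a number: the limit of > 100000 nM in this assay, at which 1 of the 4 values shown sits. Its step to the new compound can therefore be read only as a floor, an at least 2.0-fold lower number from compound 3 to compound 4 (0.30 log units; that floor lies within the scatter). The comparison with the 4-fluorophenyl compound gives a 1.5-fold lower number from compound 2 to compound 4 (0.16 log units; within the scatter), so exchanging these two groups on the nitrogen produces no real shift on this hydroxy-bearing core in this assay.

Going by these compounds, whether an amine or a carboxylic acid in place of trifluoromethyl on that ring would move the number stays open. So does the value of 3-(trifluoromethyl)phenyl on the core lacking the hydroxy.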